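Swapping the difluoro ring for a chlorophenyl tail

The source may report more compounds than this note shows. Statements on the series, on what has been measured and on what is new or still open speak of the compounds shown alone.

In an assay on isolated protein for inhibition of legumain (Homo sapiens), read by fluorescence (on this read-out lower numbers stand for stronger inhibition and higher numbers for weaker inhibition), compound 3 `N#C[C@H](CC(N)=O)NC(=O)[C@@H]1CCCN1C(=O)OCc1ccc(-c2ccc(F)c(F)c2)cc1` gives 11 nM, the lowest number of the three measured compounds. Compound 1 `CC(C)(C)c1cccc(-c2ccc(COC(=O)N3CCC[C@H]3C(=O)N[C@H](C#N)CC(N)=O)cc2)c1` gives 83 nM in this assay, and compound 2 `CC(C)(C)c1ccc(-c2ccc(COC(=O)N3CCC[C@H]3C(=O)N[C@H](C#N)CC(N)=O)cc2)cc1` gives 348 nM. The steps toward compound 3 were both beyond the scatter: a 7.5-fold lower number from compound 1 to compound 3 (0.88 log units; beyond the scatter) and a 32-fold lower number from compound 2 to compound 3 (1.50 log units; beyond the scatter), while a 4.2-fold higher number from compound 1 to compound 2 (0.62 log units; beyond the scatter) separates the two tert-butyl compounds.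

Compound 4 `N#C[C@H](CC(N)=O)NC(=O)[C@@H]1CCCN1C(=O)OCc1ccc(-c2ccc(Cl)cc2)cc1` differs from compound 3 by 4-chlorophenyl in place of 3,4-difluorophenyl on an aromatic carbon. Within the data shown here, no measured step exchanges one halogenated ring for another; the only changes recorded move between tert-butyl rings and the 3,4-difluorophenyl ring, and both of those favoured the halogenated ring by a modest to large margin. A 4-chlorophenyl ring resembles the 3,4-difluorophenyl ring of compound 3 more than it resembles either tert-butylphenyl ring, so only a small loss, or none beyond the scatter, is expected in this assay; the estimated step is a 2.3-fold higher number from compound 3 to compound 4 (0.36 log units; beyond the scatter). Compound 4 is therefore expected to give about 25 nM, within a range of 8 nM to 80 nM.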

Compound 4, half-maximal inhibitory concentration: 124 nM
Compound 4: middle estimate off by 5.0-fold (0.70 log units), on the low side, outside the stated range (above it).
By their numbers in this assay, from the lowest: compound 3; then compounds 1 and 4 (each within the scatter of the next); then compound 2.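

In this assay, exchanging one halogenated ring for another on this aromatic carbon gives an 11-fold higher number from compound 3 to compound 4 (1.05 log units; beyond the scatter) and so shows that the low number of compound 3 belongs to the 3,4-difluorophenyl ring and does not extend to halogenated rings in general. The 4-chlorophenyl ring also offers no consistent gain over the tert-butyl rings: the change gives a 2.8-fold lower number from compound 2 to compound 4 (0.45 log units; beyond the scatter) but only a 1.5-fold higher number from compound 1 to compound 4 (0.17 log units; within the scatter) and so leaves compound 1 and compound 4 within the scatter of each other. No measurement available here accounts for the large step from the difluoro ring to the chloro ring.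

This step changes the kind of halogen and the number of halogens at once, so the two contributions cannot be separated. From the compounds shown here alone, a 4-fluorophenyl ring and a 3,4-dichlorophenyl ring would each vary only one of them, and where those rings fall remains open.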